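The source may report more compounds than this note shows. Statements on the series, on what has been measured and on what is new or still open speak of the compounds shown alone.

Measured so far:
- Compound 1 `CN(C)C(=O)c1cc2cnc(Nc3ccc(NC(=O)C4(C(=O)Nc5ccc(F)cc5)CC4)cc3)nc2n1C1CCCC1`: 102%
- Compound 2 `COc1ccc(NC(=O)C2(C(=O)Nc3ccc(Nc4ncc5cc(C(=O)N(C)C)n(C6CCCC6)c5n4)cc3)CC2)cc1`: 78.5%

Among the compounds with values here, in a functional assay on A549 cells (Homo sapiens) for inhibition, read by CCK-8 assay, with a stated time of 72 h, tested at 10 uM (a lower number here means less inhibition of growth, a higher number more inhibition of growth at the concentration tested), compound 2 gives 78.5%, the lower of the two numbers so far. Compound 3 `CN(C)C(=O)c1cc2cnc(Nc3ccc(NC(=O)C4(C(=O)Nc5ccc(Cl)c(C(F)(F)F)c5)CC4)cc3)nc2n1C1CCCC1` differs from compound 2 in one place: 4-chloro-3-(trifluoromethyl)phenyl in place of 4-methoxyphenyl on an amide-type nitrogen. In short, 4-chloro-3-(trifluoromethyl)phenyl stands in place of 4-methoxyphenyl on an amide-type nitrogen.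

Within the data shown here, only one measured step bears on this change: a number 23.5 percentage points lower from compound 1 to compound 2 (beyond the scatter), with methoxy in place of fluoro on an aromatic carbon. Among the measured compounds shown here, compound 3 also lacks that methoxy, but no measured compound carries chloro or trifluoromethyl, so this step is only a loose guide. A partial return towards compound 1 seems the likeliest outcome. The expected change in this assay is a modest rise, estimated as a number 11.5 percentage points higher from compound 2 to compound 3 (beyond the scatter). Compound 3 is expected at about 90%, with an estimated range of 70% to 106%.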

Compound 3, percent growth inhibition at one concentration: 88.1%
For compound 3 the middle estimate is 1.9 percentage points above the measured one, within the range that was stated.
By their numbers in this assay, from the lowest: compounds 2 and 3 (each within the scatter of the next); then compound 1.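

On the amide-type nitrogen, 4-chloro-3-(trifluoromethyl)phenyl in place of 4-methoxyphenyl gives in this assay a number 9.6 percentage points higher from compound 2 to compound 3 (within the scatter) and so does not separate these two groups. The same group in place of 4-fluorophenyl gives a number 13.9 percentage points lower from compound 1 to compound 3 (beyond the scatter) which makes compound 1 the only one of the three whose steps to both others lie beyond the scatter. No measurement of any property of these groups is available to account for this.

Still open, as far as these compounds go, is whether a 4-chlorophenyl or a 3-(trifluoromethyl)phenyl group alone would read like compound 1 or like compound 2 and compound 3. Also open, from the compounds shown here alone, is how a non-aromatic cyclohexyl ring or a chain ending in an amine would fare on this nitrogen.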